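Swapping the Basic Amine on the Propyl Ether Chain

A few compounds are considered here, and "the series" means these few. Any claim that something is new, unique, unknown or untested is made for them only; others in the source may bear on it.

Among the measured compounds shown here, compound 1 (`COc1cc2c(Oc3ccc(NC(=O)c4nnn(-c5ccc(F)cc5)c4C(F)(F)F)cc3F)ccnc2cc1OCCCN1CCCC1`) is the only compound here with a number: in a functional assay on U-87MG ATCC cells (Homo sapiens) for cytotoxicity, read by MTT assay, with a stated time of 72 h (a higher number here means a weaker inhibitor, a lower number a stronger inhibitor), compound 1 gives 850 nM. For compound 2 (`COc1cc2c(Oc3ccc(NC(=O)c4nnn(-c5ccc(C)cc5)c4C(F)(F)F)cc3F)ccnc2cc1OCCCN1CCCC1`) the entry in this assay reads "not determined" (no result reported), so no comparison can be drawn from it. Compound 3 (`COc1cc2c(Oc3ccc(NC(=O)c4nnn(-c5ccc(F)cc5)c4C(F)(F)F)cc3F)ccnc2cc1OCCCN1CCC(C)CC1`) has not been measured; its difference from compound 1 is 4-methylpiperidin-1-yl in place of pyrrolidin-1-yl on a saturated chain carbon, three bonds along the chain from an oxygen on an aromatic ring, a change at the far end of the chain and away from the amide and the shared core. For the measured compounds named here, with no measured pair to show what such a swap does, the expectation is a step from compound 1 to compound 3 of a 1.1-fold lower number from compound 1 to compound 3 (0.03 log units; within the scatter), that is, nothing beyond the usual scatter in either direction. Compound 3 is therefore estimated at 800 nM, with a plausible range from 300 nM to 2500 nM.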

Compound 3, half-maximal inhibitory concentration: 800 nM
Compound 3: middle estimate and measured number agree at the digits printed; low and high end bracket the measured number.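

In this assay, replacing pyrrolidin-1-yl with 4-methylpiperidin-1-yl on the propyl ether chain gives a 1.1-fold lower number from compound 1 to compound 3 (0.03 log units; within the scatter). This first measured step at this place shows that the five-membered ring at the end of the chain can give way to a six-membered ring bearing a methyl group with no change beyond the usual scatter of the read-out. No information is available here to explain this outcome.

One step cannot show whether this tolerance extends to other groups at the chain end, such as morpholin-4-yl, a primary amine or a carboxylic acid. It also leaves open how a shorter or longer chain carrying the same 4-methylpiperidin-1-yl group would behave.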